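The compounds below may be only part of what the source reports. "The series", "measured", "known", "first", "only" and "open" are said of these compounds alone.

Compound 1 `CC(C)=CCC[C@]1(C)/C=C/[C@@H](OC(=O)C=C(C)C)[C@](C)(O)/C=C/C(=O)/C(CF)=C\C1`: 240 nM
Compound 2 `COC/C1=C/C[C@](C)(CCC=C(C)C)/C=C/[C@@H](OC(=O)C=C(C)C)[C@](C)(OC)/C=C/C1=O`: 16500 nM
Compound 3 `COC/C1=C/C[C@](C)(CCC=C(C)C)/C=C/[C@@H](OC(=O)C=C(C)C)[C@](C)(O)/C=C/C1=O`: 4130 nM

In a functional assay on MCF7 cells (Homo sapiens) for antiproliferative activity, read by MTT assay, with a stated time of 48 h (on this read-out lower numbers stand for stronger inhibition and higher numbers for weaker inhibition), compound 3 gives 4130 nM, the middle of the three numbers, lower than compound 2 and higher than compound 1. Compound 4 `CC(C)=CCC[C@]1(C)/C=C/[C@@H](OC(=O)C=C(C)C)[C@](C)(O)/C=C/C(=O)/C(CCl)=C\C1` carries chloro in place of methoxy on a saturated chain carbon bound to a double-bonded ring carbon. The closest evidence is a 17-fold higher number from compound 1 to compound 3 (1.24 log units; beyond the scatter), a large step at this same place, with methoxy in place of fluoro. The other step, a 4.0-fold lower number from compound 2 to compound 3 (0.60 log units; beyond the scatter), concerns a different place and bears little. For the measured compounds named here, no chloro compound has been measured, so a large drop, perhaps not quite the full reversal, is expected in this assay. The estimated change is a 10-fold lower number from compound 3 to compound 4 (1.01 log units; beyond the scatter). For compound 4, the estimated value is 400 nM, with an expected range of 130 nM to 1300 nM.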

Compound 4, half-maximal inhibitory concentration: 610 nM
Beside the measured number, compound 4's estimate is 1.5-fold (0.18 log units) below it; measured number inside the range.
By their numbers in this assay, from the lowest: compound 1; then compound 4; then compound 3; then compound 2.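

In this assay, the low number of compound 1 turns out not to depend on fluoro alone: a 6.8-fold lower number from compound 3 to compound 4 (0.83 log units; beyond the scatter) comes with chloro in place of methoxy on this saturated chain carbon. The two halogens are still not interchangeable here, since a 2.5-fold higher number from compound 1 to compound 4 (0.41 log units; beyond the scatter) separates them beyond the scatter. Nothing at hand accounts for this order of fluoro, chloro and methoxy.

The compounds shown leave open whether bromo or an amine at this place would give a number nearer that of compound 1 or that of compound 3.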